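This account rests on a few compounds, and the source may have more. Where it says the series, first, only, none or still open, it means among the compounds named here.

The measured compounds are few. Compound 1, `N#CC1=C(N)Oc2c(c3nc4ccccc4nc3c3ccccc23)C12C(=O)N(Cc1cnnn1-c1ccccc1Br)c1ccccc12`, gives in a functional assay on HCT-116 cells (Homo sapiens) for antiproliferative activity, read by MTT assay, with a stated time of 48 h (a higher number here means a weaker inhibitor, a lower number a stronger inhibitor), only a limit of the assay, > 50000 nM. Compound 2, `CC(=O)Nc1ccc(-n2nncc2CN2C(=O)C3(C(C#N)=C(N)Oc4c3c3nc5ccccc5nc3c3ccccc43)c3ccccc32)cc1`, likewise gives only a limit in this assay, > 50000 nM. Among the measured compounds shown here, compound 3, `N#CC1=C(N)Oc2c(N)cc3nc4ccccc4nc3c2C12C(=O)N(Cc1cnnn1-c1ccccc1Br)c1ccccc12`, is the one compound with a number: in this assay compound 3 gives 12400 nM.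

For the measured compounds named here, compound 3 therefore stands alone as the sole readable value, the two other entries being limits (the limit of > 50000 nM in this assay, at which 2 of the 3 values shown sit). The step considered here leads to compound 4, `COc1ccc(OC)c(-n2nncc2CN2C(=O)C3(C(C#N)=C(N)Oc4c(N)cc5nc6ccccc6nc5c43)c3ccccc32)c1`, and consists of 2,5-dimethoxyphenyl in place of 2-bromophenyl on an aromatic nitrogen. Going by the values given here, the only measured step that touches the same position is a step that the two limits leave unreadable from compound 1 to compound 2, and its two limits leave its size unreadable, so there is no measured guide to how a change of the aryl group on that aromatic nitrogen moves the number. With nothing beyond the scatter established either way, the expectation for compound 4 is a step of a 1.6-fold higher number from compound 3 to compound 4 (0.21 log units; within the scatter) from compound 3, within the scatter, and with a fair chance that the assay again reports only a limit. Compound 4 is thus estimated at 20000 nM in this assay, with a range from 6000 nM to 50000 nM.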

Compound 4, half-maximal inhibitory concentration: > 50000 nM
Compound 4: no number, only a limit (the forecaster's own chance of this, stated with the estimate: 35%); middle value at least 2.5-fold (0.39 log units) from the limit.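

At the aryl group on the aromatic nitrogen of the five-membered ring, this assay now gives a step that can be read: 2,5-dimethoxyphenyl in place of 2-bromophenyl brings an at least 4.0-fold higher number from compound 3 to compound 4 (0.60 log units; beyond the scatter). The only earlier step at this position cannot be read, so this is the first sign in the compounds shown that the aryl group here can move the number beyond the scatter, and it moves towards a weaker inhibitor. The entry for compound 4 is a limit, so the step has a direction and a minimum size but no exact size, and compound 3 with its 2-bromophenyl group remains the only compound with a number: the limit of > 50000 nM in this assay, at which 3 of the 4 values shown sit.

The compounds shown leave open whether the loss needs both methoxy groups, and whether an unsubstituted phenyl, a single methoxy group, an amine or a carboxylic acid on this phenyl ring would keep a readable number on the core of compound 3. They also leave open what the 4-acetamidophenyl group of compound 2 would give on that core, and no reason for the step can be drawn from these values.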